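The compounds below may be only part of what the source reports. "The series", "measured", "known", "first", "only" and "open" are said of these compounds alone.

Working notes on the hydroxamate series.

In an assay on isolated protein for inhibition of protein deacetylase HDAC6 (Homo sapiens), read by fluorescence (on this read-out higher numbers stand for weaker inhibition and lower numbers for stronger inhibition), compound 1 `Cc1cc(F)cc(C)c1Oc1ccc(C(C)(C)O)cc1-c1cn(C)c(=O)c2[nH]c(C(=O)NCc3ccc(C(=O)NO)cc3)cc12` gives 39.3 nM. For the measured compounds named here, compound 2 `Cn1cc(-c2ccccc2Oc2ccccc2)c2cc(C(=O)NCCCC(=O)NO)[nH]c2c1=O`, which pairs a different core with a short chain hydroxamate, gives 144 nM in this assay; the two numbers differ beyond the usual scatter, and compound 1 stands as the lower of the two numbers so far. Going by the values given here, compound 3 `Cn1cc(-c2ccccc2Oc2ccccc2)c2cc(C(=O)NCc3ccc(C(=O)Nc4ccccc4N)cc3)[nH]c2c1=O` reaches only the limit of this assay, > 500 nM; that is a limit, not a number, and it is the one value here that sits at the limit of > 500 nM in this assay, at which 1 of the 3 values shown sits.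

Compound 4 `Cc1cc(F)cc(C)c1Oc1ccc(C(C)(C)O)cc1-c1cn(C)c(=O)c2[nH]c(C(=O)NCCCCCCC(=O)NO)cc12` keeps the core of compound 1 and differs only in the hydroxamate carrier: 5-(hydroxycarbamoyl)pentyl in place of 4-(hydroxycarbamoyl)phenyl on a saturated chain carbon bound to an amide-type nitrogen. Among the compounds with values here, no measured pair shows this change on a shared core, so the size of the step is open. Taking the chain hydroxamate of compound 2 at 144 nM as the only pointer, a modest weakening is expected, the estimated step being a 2.5-fold higher number from compound 1 to compound 4 (0.41 log units; beyond the scatter). Compound 4 is thus expected to give about 100 nM in this assay, within a range of 40 nM to 300 nM.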

Compound 4, half-maximal inhibitory concentration: 17.2 nM
Compound 4: middle estimate off by 5.8-fold (0.76 log units), on the high side, and the stated range ends above it.
By their numbers in this assay, from the lowest: compound 4; then compound 1; then compound 2. At a limit, above all of these: compound 3.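

For the compounds shown here, this is the only pair that differs in one place, and it gives the first direct reading at this position: in this assay, 5-(hydroxycarbamoyl)pentyl in place of 4-(hydroxycarbamoyl)phenyl, on a saturated chain carbon bound to an amide-type nitrogen, gives a 2.3-fold lower number from compound 1 to compound 4 (0.36 log units; beyond the scatter). On this core, then, the hydroxamate carrier needs no six-membered aromatic ring to reach a low number, and the open chain gives the lower of the two, though this rests on one pair alone. Nothing at hand accounts for the direction of this step.

On these data alone, whether a longer chain or a shorter one would move the number further on this core remains open. So does whether a carboxylic acid could stand in place of the hydroxamate at the end of the pentyl chain.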